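A Chloro Swap Among the Thiosemicarbazones

The compounds below may be only part of what the source reports. "The series", "measured", "known", "first", "only" and "open" are said of these compounds alone.

Values so far in a functional assay on UACC-62 cells (Homo sapiens) for cytotoxicity, read by sulforhodamine B assay (a higher number here means that more compound is tolerated, a lower number that less compound is tolerated), are these
compound 1 `CC1=CC[C@@H]([C@@](C)(O)CCCC(C)(C)NC(=S)N/N=C\c2ccccc2)CC1` gives 48400 nM here
compound 2 `CC1=CC[C@@H]([C@@](C)(O)CCCC(C)(C)NC(=S)N/N=C\c2ccccc2[N+](=O)[O-])CC1` gives 49300 nM here
compound 3 `CC1=CC[C@@H]([C@@](C)(O)CCCC(C)(C)NC(=S)N/N=C\c2cccc([N+](=O)[O-])c2)CC1` gives 49300 nM here

Compound 3 stands level with compound 2 at the digits shown, and all three values lie within the scatter of one another. Compound 4 `CC1=CC[C@@H]([C@@](C)(O)CCCC(C)(C)NC(=S)N/N=C\c2cccc(Cl)c2)CC1` has not yet been measured. The difference chloro in place of nitro on an aromatic carbon amounts to chloro in place of nitro on an aromatic carbon.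

Among the measured compounds shown here, three measured steps bear on this change. Nitro in place of hydrogen on an aromatic carbon gave a 1.0-fold higher number from compound 1 to compound 2 (0.01 log units; within the scatter) in one case and a 1.0-fold higher number from compound 1 to compound 3 (0.01 log units; within the scatter) in the other. Exchanging 2-nitrophenyl for 3-nitrophenyl gave no change at the digits printed from compound 2 to compound 3 (within the scatter) as the third step. For the measured compounds named here, no chloro compound has been measured, so these steps speak only for nitro and hydrogen. Even so, none of them left the scatter, and none beyond it is expected now. The step expected for compound 4 is a 1.0-fold lower number from compound 3 to compound 4 (0.02 log units; within the scatter) as the working estimate. Compound 4 is estimated at 47000 nM with an expected range from 28000 nM to 65000 nM in this assay when it is read.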

Compound 4, concentration lethal to 50% of the cells: 42700 nM
Compound 4: middle estimate off by 1.1-fold (0.04 log units), on the high side, and the stated range covers the measured number.
By their numbers in this assay, from the lowest: compounds 4, 1, 2 and 3 (each within the scatter of the next).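

In this assay, chloro in place of nitro, one heavy atom for three and no hydrogen-bond acceptors for two, leaves the reading within the scatter, with a 1.2-fold lower number from compound 3 to compound 4 (0.06 log units; within the scatter). The chloro compound also stays within the scatter of the 2-nitrophenyl compound, with a 1.2-fold lower number from compound 2 to compound 4 (0.06 log units; within the scatter), and of the compound carrying only hydrogen on the ring, with a 1.1-fold lower number from compound 1 to compound 4 (0.05 log units; within the scatter), so the flat picture among hydrogen and nitro now extends to a halogen. The compounds shown come with no supporting data that could account for this flatness.

Going by these compounds, whether an amine, a carboxylic acid or a methoxy group on this ring would leave the scatter remains open. Also open, on these data alone, is whether a longer chain in place of the one on the shared core would change the reading.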